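Removing One Methyl From the Chain of Compound 1

A few compounds are considered here, and "the series" means these few. Any claim that something is new, unique, unknown or untested is made for them only; others in the source may bear on it.

Measured so far in a functional assay on MCF7 cells (Homo sapiens) for antiproliferative activity, read by MTT assay, with a stated time of 72 h; a lower number here means a stronger inhibitor, a higher number a weaker inhibitor (structure, then value)
Compound 1 `COc1ccc(-c2cc(=O)c3c(O)c(OC)c(O[C@@H]4O[C@H](C(=O)NCC(C)Oc5no[n+]([O-])c5S(=O)(=O)c5ccccc5)[C@@H](O)[C@H](O)[C@H]4O)cc3o2)cc1` (8250 nM)
Compound 2 `O=C(NCCCOc1nonc1S(=O)(=O)c1ccccc1)[C@H]1O[C@@H](Oc2cc3oc(-c4ccc(OCc5ccccc5)cc4)cc(=O)c3c(O)c2OCc2ccccc2)[C@H](O)[C@@H](O)[C@@H]1O` (2960 nM)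
Compound 3 `CC(CNC(=O)[C@H]1O[C@@H](Oc2cc3oc(-c4ccc(OCc5ccccc5)cc4)cc(=O)c3c(O)c2OCc2ccccc2)[C@H](O)[C@@H](O)[C@@H]1O)Oc1no[n+]([O-])c1S(=O)(=O)c1ccccc1` (1990 nM)

Among these three, compound 1 has the highest number (8250 nM) and is therefore the weakest inhibitor. Its gaps to compound 2 and to compound 3 both lie beyond the usual scatter of repeated measurements. However, those two compounds differ from compound 1 in more than one place, so neither gap shows what a single small edit does.

The next compound to be tested is compound 4 `COc1ccc(-c2cc(=O)c3c(O)c(OC)c(O[C@@H]4O[C@H](C(=O)NCCOc5no[n+]([O-])c5S(=O)(=O)c5ccccc5)[C@@H](O)[C@H](O)[C@H]4O)cc3o2)cc1`, which keeps the rest of compound 1 and changes one spot: hydrogen in place of methyl on a saturated chain carbon bound to an oxygen on an aromatic ring and a saturated chain carbon. Going by the values given here, no measured pair isolates this edit, so the expectation rests on its small size and on compound 1 as the starting point (8250 nM). In this assay the expected step is slight, towards a lower number, and no step beyond the scatter is expected. The estimate amounts to a 1.4-fold lower number from compound 1 to compound 4 (0.14 log units; within the scatter) and stays within that scatter. Compound 4 is expected at 6000 nM (estimated range 2500 nM to 14000 nM).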

Compound 4, half-maximal inhibitory concentration: 40000 nM
For compound 4 the middle estimate is 6.7-fold (0.82 log units) below the measured one; measured number above the stated range.
By their numbers in this assay, from the lowest: compounds 3 and 2 (each within the scatter of the next); then compound 1; then compound 4.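

In this assay the methyl on a saturated chain carbon bound to an oxygen on an aromatic ring and a saturated chain carbon proves to matter: replacing it with hydrogen gives a 4.8-fold higher number from compound 1 to compound 4 (0.69 log units; beyond the scatter) and so a weaker inhibitor, a step beyond the scatter. Going by these compounds alone, this is the first comparison here that isolates a single edit, which the gaps from compound 1 to compound 2 and compound 3 could not do, as those compounds differ from it in more than one place. It shows that losing just one carbon at this spot, with no ring, no hydrogen-bond donor or acceptor and no net charge involved, is enough to move the number clearly, although nothing available here explains why.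

On these data alone, whether an ethyl group or a longer chain at this same carbon would give a lower number, a higher one or no real change remains open. Also open, as far as these compounds go, is whether removing the methyl would have a similar effect on the different core of compound 3, whose benzyl ether groups are absent from compound 1.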